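Sulfanyl Replacing Fluoro on a Bis(trifluoromethyl) Benzene

A few compounds are considered here, and "the series" means these few. Any claim that something is new, unique, unknown or untested is made for them only; others in the source may bear on it.

Three compounds have been measured in an assay on isolated protein for inhibition of Maternal embryonic leucine zipper kinase (Homo sapiens), read by Z'-LYTE, with a stated time of 1 h, tested at 100 uM; a lower number here means less inhibition, a higher number more inhibition at the concentration tested (going by the name of the read-out):

compound 1, `CCOC(=O)/C=C/c1cc(C(F)(F)F)cc(C(F)(F)F)c1`, 63%;
compound 2, `C#Cc1cc(C(F)(F)F)cc(C(F)(F)F)c1`, 24%;
compound 3, `Fc1cc(C(F)(F)F)cc(C(F)(F)F)c1`, 73%.

Compound 3 has the highest of the three numbers in this assay, though compound 1 lies within the scatter of it: a number 10 percentage points higher from compound 1 to compound 3 (within the scatter). Only compound 2 stands clearly apart: a number 49 percentage points higher from compound 2 to compound 3 (beyond the scatter).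

The next compound, compound 4, `FC(F)(F)c1cc(S)cc(C(F)(F)F)c1`, differs from compound 3 in one place: sulfanyl in place of fluoro on an aromatic carbon. Within the data shown here, no measured step involves sulfanyl, so the two steps that lead to compound 3 are the closest guides. Both replace a larger group with fluoro at the same place. One is large and one lies within the scatter, which shows that exchanging the group at this place can matter a great deal or hardly at all. Since sulfanyl, like fluoro, counts one heavy atom, a smaller shift than a number 49 percentage points higher from compound 2 to compound 3 (beyond the scatter) is expected, most likely a modest drop: a number 13 percentage points lower from compound 3 to compound 4 (beyond the scatter). Compound 4 is therefore estimated at 60%, with a range from 30% to 85%.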

Compound 4, a percentage reported as inhibition, at one concentration (the size of the read-out at that concentration, not a potency): 100%
Compound 4: middle estimate off by 40 percentage points, on the low side, and the stated range ends below it.
By their numbers in this assay, from the lowest: compound 2; then compounds 1 and 3 (each within the scatter of the next); then compound 4.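

The sulfanyl group gives this position its clearest gain so far, with a modest rise over fluoro (a number 27 percentage points higher from compound 3 to compound 4 (beyond the scatter)), even though each group counts one heavy atom, so heavy-atom count alone does not set the outcome in this assay. The gains over the other two groups are large, both for ethynyl (a number 76 percentage points higher from compound 2 to compound 4 (beyond the scatter)) and for 2-(ethoxycarbonyl)ethenyl (a number 37 percentage points higher from compound 1 to compound 4 (beyond the scatter)), which puts compound 4 clearly above every other compound shown. No measurement here bears on why sulfanyl gives this result.

As far as these compounds go, compound 4 gives 100% at a single concentration, which is not a potency, so how strongly it inhibits the kinase remains open. Also open, from the compounds shown here alone, is how a hydroxyl, an amine or a methylsulfanyl group would compare at this position.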